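Cyclopropyl to isobutyl on the sulfonamide nitrogen

The source may hold more compounds than are shown below. What is called first, only, known or untested is meant among the compounds shown, and "the series" means these compounds.

Compound 1 `O=C(NO)c1ccc(CN(C2CC2)S(=O)(=O)c2cc(F)c(F)c(F)c2F)cc1` and compound 2 `CC(C)N(Cc1ccc(C(=O)NO)cc1)Cc1cc(F)c(F)c(F)c1F` share the hydroxamic acid core with a tetrafluorophenyl group attached through the nitrogen substituent. In an assay on Sf9 cells for inhibition of histone deacetylase 8 (Homo sapiens), read by fluorescence and mobility shift assay (on this read-out higher numbers stand for weaker inhibition and lower numbers for stronger inhibition), compound 1 gives > 1000 nM, which is a limit of the assay and not a number. In this assay compound 2 gives > 1000 nM, again a limit. Among the measured compounds shown here, compound 1 therefore stands at the limit of > 1000 nM in this assay, at which 2 of the 2 values shown sit; no numerical value is available for it, and no step between measured compounds can be drawn.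

Compound 3 `CC(C)CN(Cc1ccc(C(=O)NO)cc1)S(=O)(=O)c1cc(F)c(F)c(F)c1F` differs from compound 1 by isobutyl in place of cyclopropyl on a sulfonamide nitrogen; the sulfonyl and the rest of compound 1 are kept. With compound 1 at the limit of > 1000 nM in this assay, at which 2 of the 2 values shown sit, the step is expected to stay within the usual scatter and most likely to leave compound 3 at the same limit; the expected step is a step that the limit leaves unreadable from compound 1 to compound 3. For compound 3 in this assay the expected value is 3000 nM, between 800 nM and 20000 nM.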

Compound 3, half-maximal inhibitory concentration: > 1000 nM
Compound 3 gave a limit, no number; the forecaster's own chance of this, stated with the estimate: 75%; the middle value lies beyond the limit too.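

In this assay compound 3 gives > 1000 nM, a limit and not a number; compound 1 also gives only a limit, so no step can be read between them. The compounds shown leave open whether isobutyl in place of cyclopropyl changes inhibition at all: the limit of > 1000 nM in this assay, at which 3 of the 3 values shown sit.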